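The source may hold more compounds than are shown below. What is called first, only, known or untested is meant among the compounds shown, and "the series" means these compounds.

Among the measured compounds shown here, in a functional assay on the whole organism for agonist activity, with Mus musculus as the target (a higher number here means that more compound is needed for the effect, a lower number that less compound is needed), compound 1 (`CN1CCN(CC#CCn2ccnc2)C1=O`) gives 1.4 mg/kg and holds the higher of the two numbers so far, while compound 2 (`CN(C)CC#CCN1CCN(C)C1=O`) gives 0.54 mg/kg in the same read-out. For the measured compounds named here, compound 3 (`CC(C#CCn1ccnc1)N1CCN(C)C1=O`) keeps the core of compound 1 and has methyl in place of hydrogen on a saturated chain carbon bound to an amide-type nitrogen in a ring and a triple-bonded carbon as its single change. Going by the values given here, the only measured step is a 2.6-fold lower number from compound 1 to compound 2 (0.41 log units; beyond the scatter) and it lies at a different place, so it offers only a rough guide to size. Among the compounds with values here, no step at the new place has been measured. The expected step is a 1.8-fold higher number from compound 1 to compound 3 (0.25 log units; within the scatter) and its size is taken as similarly modest, leaning to a higher number, with the direction uncertain. Compound 3 is expected at 2.5 mg/kg with an estimated range from 0.6 mg/kg to 10 mg/kg for now.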

Compound 3, dose for half-maximal effect: > 100 mg/kg
Compound 3 was reported as a limit; the forecaster's own chance of this, stated with the estimate: 20%; at least 40-fold (1.60 log units) between middle value and limit.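

In this assay, the saturated chain carbon bound to an amide-type nitrogen in a ring and a triple-bonded carbon proves highly sensitive: methyl in place of hydrogen gives an at least 71-fold higher number from compound 1 to compound 3 (1.85 log units; beyond the scatter). This large step exceeds the only earlier one, a modest 2.6-fold lower number from compound 1 to compound 2 (0.41 log units; beyond the scatter), which lies at a different place, so this single added carbon outweighs the exchange of 1H-imidazol-1-yl for dimethylamino. The value of compound 3 is a limit, and it is the only one in the series so far: the limit of > 100 mg/kg in this assay, at which 1 of the 3 values shown sits.

From the compounds shown here alone, it remains open whether the rise belongs to methyl alone or would also follow from ethyl, hydroxyl or fluorine at this place. Going by these compounds, it is equally open whether methyl here would have the same effect with the dimethylamino group of compound 2.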